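Removing a Bromo Group From a Cytotoxic Isatin-Derived Series

The source may report more compounds than this note shows. Statements on the series, on what has been measured and on what is new or still open speak of the compounds shown alone.

Measured compounds:
- compound 1, `O=C1C(=O)N(CN(c2ccccc2)c2ccccc2)c2ccccc21`: 73000 nM
- compound 2, `Cc1ccc2nc(/N=C3\C(=O)N(CN(C)C)c4cccc(Br)c43)sc2c1`: 21800 nM
- compound 3, `O=C1C(=O)N(CN(c2ccccc2)c2ccccc2)c2cccc(Br)c21`: 85800 nM

Of the compounds shown here, three have been tested in an ADME assay on MCF-10A cells (Homo sapiens) for cytotoxicity, read by sulforhodamine B assay, with a stated time of 48 h; on this read-out higher numbers stand for weaker inhibition of growth and lower numbers for stronger inhibition of growth. Compound 1 gives 73000 nM, compound 3 gives 85800 nM, and compound 2 gives 21800 nM, the lowest of the three; its distance to compound 1 and to compound 3 is beyond the usual scatter. Compound 1 and compound 3 differ in only one place, (hydrogen in place of bromo on an aromatic carbon), and this change made a step of a 1.2-fold lower number from compound 3 to compound 1 (0.07 log units; within the scatter), so on this evidence the bromo group matters little.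

Compound 4, `Cc1ccc2nc(/N=C3\C(=O)N(CN(C)C)c4ccccc43)sc2c1`, has not yet been measured. It relates to compound 2 exactly as compound 1 relates to compound 3: hydrogen in place of bromo on an aromatic carbon. The place of the change is the same in both pairs, so this is the same change, now made on the core of compound 2. How the core of compound 2 differs from that of compound 3 is not broken down here.

Because a 1.2-fold lower number from compound 3 to compound 1 (0.07 log units; within the scatter) lay within the scatter, the expected step for compound 4 is small, estimated at a 1.1-fold lower number from compound 2 to compound 4 (0.06 log units; within the scatter). Going by the values given here, compound 4 is therefore expected to give about 19000 nM in this assay, most likely between 9000 nM and 42000 nM, resting on the single comparable step seen so far.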

Compound 4, concentration for 50% growth inhibition: 13400 nM
Beside the measured number, compound 4's estimate is 1.4-fold (0.15 log units) above it; measured number inside the range.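

In this assay, putting hydrogen in place of bromo on the core of compound 2 gives a step of a 1.6-fold lower number from compound 2 to compound 4 (0.21 log units; within the scatter), so the measured difference is no larger than repeated measurements of one compound could produce. Set beside the earlier step, the two results do not differ, and the change behaves alike on both cores: the same change on two cores in this assay, a 1.2-fold lower number (0.07 log units; within the scatter) from compound 3 to compound 1 and a 1.6-fold lower number (0.21 log units; within the scatter) from compound 2 to compound 4, 1.4-fold (0.14 log units) apart, within the scatter of two such steps This shows that, for these two pairs, removing the bromo group leaves growth inhibition in this test without a change that can be told from scatter, but two pairs in a single assay do not show that the same would hold on every core in the series, nor do they show that the bromo group can never matter.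

The compounds shown carry only bromo or hydrogen at this place, so what a chloro group, a methoxy group or an amine would do there remains open. Also open, as far as these compounds go, is whether the step stays this small on a third core, since the evidence so far rests on two cores alone.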